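Swapping the Ring on the Amide Nitrogen of Compound 2

The source may hold more compounds than are shown below. What is called first, only, known or untested is meant among the compounds shown, and "the series" means these compounds.

Compound 2 `COc1ccc2nc(C)cc(OCC(=O)NC3CONC3=O)c2c1` shares its core with compound 1 `COc1ccc2nc(C)cc(OCC(=O)Nc3ccc(Cl)cc3Cl)c2c1` and differs from it only in the group on the amide nitrogen. In a physicochemical assay for solubility, in phosphate buffer, measured as kinetic solubility, with a stated time of 1 h, at pH 7.4 (a lower number here means a less soluble compound, a higher number a more soluble compound), compound 1 gives 20500 nM. In this assay compound 2 gives >= 166000 nM, which is a limit of the assay rather than a number. For the measured compounds named here, the single measured step, an at least 8.0-fold higher number from compound 1 to compound 2 (0.90 log units; beyond the scatter), saw an aromatic ring leave this position as the number rose, and the limit of >= 166000 nM in this assay, at which 1 of the 2 values shown sits, marks where compound 2 now sits. Compound 3 `COc1ccc2nc(C)cc(OCC(=O)NNC(=O)c3ccncc3)c2c1` differs from compound 2 in a group of 9 heavy atoms (6 carbon, 2 nitrogen, 1 oxygen; one six-membered aromatic ring with 1 hetero atom) in place of a group of 6 heavy atoms (3 carbon, 1 nitrogen, 2 oxygen; one five-membered non-aromatic ring with 2 hetero atoms), on an amide-type nitrogen. Here an aromatic ring returns to the same position, although this one holds a nitrogen, and the group leaving is a non-aromatic ring. The step of an at least 2.0-fold lower number from compound 2 to compound 3 (0.31 log units; beyond the scatter) is therefore expected to be modest and downward, with a fair chance that compound 3 also reaches the limit. Compound 3 is estimated at 80000 nM, within 20000 nM to 166000 nM.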

Compound 3, solubility: >= 375000 nM
Compound 3: a limit, no number; the forecaster's own chance of this, stated with the estimate: 30%; at least 4.6-fold (0.67 log units) between middle value and limit.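

Compound 3 carries an aromatic ring on this amide-type nitrogen and still reaches a limit of the assay rather than a number: the limit of >= 375000 nM in this assay, at which 1 of the 3 values shown sits.

Set against compound 1, ((pyridin-4-yl)carbonyl)amino in place of 2,4-dichlorophenyl gives an at least 18-fold higher number from compound 1 to compound 3 (1.26 log units; beyond the scatter), so the mere presence of an aromatic ring does not separate these two compounds. Compound 2 and compound 3 both stand as limits, and the step between them cannot be read.

Still open, as far as these compounds go, is which part of the change from compound 1 to compound 3 goes with the higher number: the chlorine atoms that leave, the nitrogen in the ring, or the added carbonyl. An unsubstituted phenyl ring on this nitrogen, read in this assay, would help to separate these parts.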